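The source may report more compounds than this note shows. Statements on the series, on what has been measured and on what is new or still open speak of the compounds shown alone.

Measured so far in an ADME assay on HepG2 2.2.15 cells (Homo sapiens) for cytotoxicity, read by MTT assay, with a stated time of 8 days; a lower number here means that less compound is tolerated, a higher number that more compound is tolerated:
compound 1 `N#Cc1ccc(Cn2nc(-c3cc(Cl)c(NCCO)nc3F)c3ccccc3c2=O)cc1` gives 32100 nM
compound 2 `CN(C)c1ccc(-c2nn(Cc3ccc(C#N)cc3)c(=O)c3ccccc23)c(F)n1` gives 79200 nM
compound 3 `Cc1c(-c2ccc(F)nc2F)nn(Cc2ccc(Cl)cc2)c(=O)c1C` gives 52900 nM

Compound 2 at 79200 nM lies within the usual scatter of compound 3 at 52900 nM on this scale. Compound 1 at 32100 nM has a number lower than compound 2 by more than the scatter.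

Compound 4 `CNc1ccc(-c2nn(Cc3ccc(C#N)cc3)c(=O)c3ccccc23)c(F)n1` has not been measured. It carries hydrogen in place of methyl on a nitrogen on an aromatic ring so dimethylamino becomes methylamino. Going by the values given here, no two measured compounds differ in just one place, so no direct precedent exists. The three measured values lie close together, so no change beyond the scatter is expected in this assay and the direction is uncertain. The expected step of a 1.3-fold lower number from compound 2 to compound 4 (0.12 log units; within the scatter) stays within the scatter. The estimated value for compound 4 is 60000 nM (expected range 28000 nM to 115000 nM).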

Compound 4, half-maximal cytotoxic concentration: > 100000 nM
Compound 4: only a limit was reported; the forecaster's own chance of this, stated with the estimate: 15%; at least 1.6-fold (0.22 log units) between middle value and limit.
By their numbers in this assay, from the lowest: compounds 1, 3 and 2 (each within the scatter of the next, the first and the last beyond it). At a limit, above all of these: compound 4.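

In this assay compound 4 gives > 100000 nM as a limit of the assay, not a number: the limit of > 100000 nM in this assay, at which 1 of the 4 values shown sits. Going from dimethylamino to methylamino on this nitrogen gives an at least 1.2-fold higher number from compound 2 to compound 4 (0.10 log units; that floor lies within the scatter) as the first comparison here of two compounds that differ in one place. From the compounds shown here alone, this change therefore does not lower the number, but the true size of the step stays unknown.

Going by these compounds, whether a plain amine or a longer chain such as ethylamino on this nitrogen would also leave the number this high stays open.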